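Exchanging the aryl group on the aromatic nitrogen: compound 4

A few compounds are considered here, and "the series" means these few. Any claim that something is new, unique, unknown or untested is made for them only; others in the source may bear on it.

Of the compounds shown here, three built on one shared core have been tested in a functional assay on MCF7 cells (Homo sapiens) for antiproliferative activity, read by MTT assay, with a stated time of 48 h; on this read-out higher numbers stand for weaker inhibition and lower numbers for stronger inhibition. Compound 1 `Cc1cccc(-n2nncc2CN2C(=O)C3(C(C#N)=C(N)Oc4c(N)cc5nc6ccccc6nc5c43)c3ccccc32)c1` reports only a limit of the assay, > 50000 nM. Compound 2 `N#CC1=C(N)Oc2c(N)cc3nc4ccccc4nc3c2C12C(=O)N(Cc1cnnn1-c1ccc(Cl)cc1)c1ccccc12` likewise reports only a limit, > 50000 nM. Going by the values given here, compound 3 `N#CC1=C(N)Oc2c(N)cc3nc4ccccc4nc3c2C12C(=O)N(Cc1cnnn1-c1ccccc1Br)c1ccccc12` is the sole compound to give a number, 30700 nM, and so it stands as the one readable point among the three. The step of an at least 1.6-fold lower number from compound 1 to compound 3 (0.21 log units; that floor lies within the scatter) and the step of an at least 1.6-fold lower number from compound 2 to compound 3 (0.21 log units; that floor lies within the scatter) both rest on that limit, (the limit of > 50000 nM in this assay, at which 2 of the 3 values shown sit), while the step that the two limits leave unreadable from compound 1 to compound 2 cannot be read at all.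

Compound 4 `CC(=O)Nc1ccc(-n2nncc2CN2C(=O)C3(C(C#N)=C(N)Oc4c(N)cc5nc6ccccc6nc5c43)c3ccccc32)cc1` differs from compound 3 at the same aromatic nitrogen: 4-acetamidophenyl in place of 2-bromophenyl on an aromatic nitrogen. Every measured step concerns an exchange of the aryl group at this nitrogen, and none of them shows a change that rises beyond the scatter; two of them end at the limit. On this evidence an exchange there is expected to leave the number near where compound 3 sits or to return it to the limit, so the step of a 1.5-fold higher number from compound 3 to compound 4 (0.17 log units; within the scatter) is estimated to be small. Compound 4 is therefore expected to give about 45000 nM in this assay, with a range from 15000 nM to 120000 nM, and a fair chance that only a limit is reported.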

Compound 4, half-maximal inhibitory concentration: > 50000 nM
Compound 4 ended at the assay's limit; the forecaster's own chance of this, stated with the estimate: 55%; middle value at least 1.1-fold (0.04 log units) from the limit.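

In this assay, the aryl group on the aromatic nitrogen now also covers 4-acetamidophenyl, which brings a hydrogen-bond donor and a hydrogen-bond acceptor that none of the earlier aryl groups carried, and the exchange gives an at least 1.6-fold higher number from compound 3 to compound 4 (0.21 log units; that floor lies within the scatter) and so adds no readable gain at this position. The steps to compound 4 from compound 1 and from compound 2 have limits at both ends and cannot be read, so nothing can be said about how these three aryl groups rank against one another. Going by these compounds alone, compound 3 remains the only compound with a number, and the series at this position now rests mostly on a single limit: the limit of > 50000 nM in this assay, at which 3 of the 4 values shown sit.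

As far as these compounds go, all four compounds carry a six-membered aromatic ring of carbon only on this nitrogen, so it remains open how a saturated group such as cyclohexyl, or a benzyl group, would read out. From the compounds shown here alone, it is also open whether an aryl ring bearing an amine or a carboxylic acid, or a 2-chlorophenyl group in place of 2-bromophenyl, would give a number at all, and whether any such number would stand beyond the scatter from that of compound 3.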